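Swapping bromo for methyl on compound 3

The compounds below may be only part of what the source reports. "The series", "measured", "known", "first", "only" and "open" are said of these compounds alone.

In a functional assay on MCF7 cells (Homo sapiens) for antiproliferative activity, read by MTT assay (a higher number here means a weaker inhibitor, a lower number a stronger inhibitor), compound 1 (`COc1ccc(-c2ccnc(Nc3ccc([N+](=O)[O-])cc3)n2)cc1`) gives 770 nM, compound 2 (`COc1ccc(-c2ccnc(Nc3ccc(Cl)cc3Cl)n2)cc1`) gives 4170 nM and compound 3 (`Clc1ccc(Nc2nccc(-c3ccc(Br)cc3)n2)c(Cl)c1`) gives 2490 nM on the same read-out. Compound 3 therefore stands within the usual scatter of compound 2, while compound 1 has a clearly lower number, beyond that scatter.

Compound 4 (`Cc1ccc(-c2ccnc(Nc3ccc(Cl)cc3Cl)n2)cc1`) differs from compound 3 in one place: methyl in place of bromo on an aromatic carbon with methyl in place of bromo on an aromatic carbon, para to a large group. In other words, 4-bromophenyl becomes 4-methylphenyl.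

Among the compounds with values here, one measured step bears on this change. At the same place, bromo in place of methoxy gave a 1.7-fold lower number from compound 2 to compound 3 (0.22 log units; within the scatter) and so stayed inside the scatter. Compound 1 differs from compound 3 in more than one place and says little about this swap. Within the data shown here, no measured compound yet carries methyl here, so the guide is thin. Going by that single step, no change beyond the scatter is expected in this assay for this swap. The estimated step is a 1.2-fold higher number from compound 3 to compound 4 (0.08 log units; within the scatter) and is expected to be small. Compound 4 is expected at 3000 nM with an estimated range from 1400 nM to 6300 nM around that middle.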

Compound 4, half-maximal inhibitory concentration: > 1000000 nM
Compound 4: no number, only a limit; the forecaster's own chance of this, stated with the estimate: 5%; middle value at least 330-fold (2.52 log units) away from the limit.
By their numbers in this assay, from the lowest: compound 1; then compounds 3 and 2 (each within the scatter of the next). At a limit, above all of these: compound 4.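

The reading for compound 4 is a limit of the assay and not a number: the limit of > 1000000 nM in this assay, at which 1 of the 4 values shown sits. Even so, the steps show that this place on the aromatic ring, para to a large group, is far from indifferent to what sits there in this assay: methyl in place of bromo gives an at least 400-fold higher number from compound 3 to compound 4 (2.60 log units; beyond the scatter), and methyl in place of methoxy gives an at least 230-fold higher number from compound 2 to compound 4 (2.37 log units; beyond the scatter). Within the data shown here, the only earlier step at this place, a 1.7-fold lower number from compound 2 to compound 3 (0.22 log units; within the scatter), stayed inside the scatter and gave no hint of such a drop, and now a swap between two groups that each count one heavy atom, with no ring, no hydrogen-bond donor or acceptor and no net charge, separates a measurable compound from one that reaches the limit.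

As far as these compounds go, how far the true value of compound 4 lies past its limit stays open, as does whether methyl would have the same effect with the 4-nitrophenyl-type partner of compound 1 on the other side of the core. Also open, from the compounds shown here alone, is whether the sharp drop belongs to methyl alone or would extend to a longer chain such as ethyl, to an amine or to chloro at this same place.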